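Methoxy for fluoro on the fused ring: notes on compound 4

This account rests on a few compounds, and the source may have more. Where it says the series, first, only, none or still open, it means among the compounds named here.

Measured so far:
- compound 1 `Cc1ccc(-c2ccc(F)cc2)n1-c1ccc(-c2nc3ccccc3s2)cc1`: 3180 nM
- compound 2 `Cc1ccc(-c2ccc(F)cc2)n1-c1ccc(-c2nc3ccc(F)cc3s2)cc1`: 2800 nM
- compound 3 `COc1ccc(-c2ccc(C)n2-c2ccc(-c3nc4ccc(F)cc4s3)cc2)cc1`: 2550 nM

In a functional assay on MCF7 cells (Homo sapiens) for cytotoxicity, read by MTT assay, with a stated time of 72 h (on this read-out higher numbers stand for weaker inhibition and lower numbers for stronger inhibition), compound 2 gives 2800 nM, the second highest of the three numbers, though its gaps to compound 1 and compound 3 are both within the scatter. Compound 4 `COc1ccc2nc(-c3ccc(-n4c(C)ccc4-c4ccc(F)cc4)cc3)sc2c1` carries methoxy in place of fluoro on an aromatic carbon, on an aromatic carbon of a six-membered aromatic ring of carbon only, part of a fused or bridged system of two rings. Among the measured compounds shown here, two steps bear on it: a 1.1-fold lower number from compound 1 to compound 2 (0.06 log units; within the scatter) and a 1.1-fold lower number from compound 2 to compound 3 (0.04 log units; within the scatter), the latter the same exchange on a different ring. Neither rises above the scatter, so no step beyond the scatter is expected in this assay. Compound 4 is therefore estimated at 2800 nM, range 1400 nM to 5600 nM, meaning an expected step of no change at the digits printed from compound 2 to compound 4 (within the scatter).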

Compound 4, half-maximal inhibitory concentration: 2800 nM
Compound 4: middle estimate and measured number agree at the digits printed, and the stated range covers the measured number.
By their numbers in this assay, from the lowest: compounds 3, 2, 4 and 1 (each within the scatter of the next).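

On the fused ring, methoxy in place of fluoro gives no change at the digits printed from compound 2 to compound 4 (within the scatter) in this assay, so the exchange is now read at this position and not only on a different ring. Methoxy in place of hydrogen at this carbon gives a 1.1-fold lower number from compound 1 to compound 4 (0.06 log units; within the scatter), so in this assay neither step leaves the scatter. Nothing available accounts for this flat reading.

Going by these compounds, whether an amine or a carboxylic acid on this carbon would give a step beyond the scatter remains open. Also open, on these data alone, is whether a longer alkoxy chain here would do so.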